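The source may hold more compounds than are shown below. What is called first, only, known or untested is meant among the compounds shown, and "the series" means these compounds.

Working notes on the series. Three compounds built on the same core have so far been run in an assay on HEK293 cells for binding affinity to 5-hydroxytryptamine receptor 7 (Homo sapiens), read by radioligand binding, tested at 1 uM; a lower number here means less inhibition, a higher number more inhibition at the concentration tested (going by the name of the read-out). Compound 1 `Brc1ccc2ccn(CCN3CCN4CCCCC4C3)c2c1` gives 78% in this assay. Compound 2 `CC1CN(CCn2ccc3ccc(Br)cc32)CCN1` gives 52%. Compound 3 `CN1CCCN(CCn2ccc3ccc(Br)cc32)CC1` gives 93%, the highest of the three numbers; the nearest of the others is compound 1, lower by a margin beyond the scatter, and the furthest is compound 2, lower by a larger margin, also beyond the scatter. Among the compounds with values here, no two of the measured compounds differ in one place only, so no single step between them is available to gauge what a change on the aromatic ring is worth.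

The next compound, compound 4 `CN1CCCN(CCn2ccc3ccc(F)cc32)CC1`, is compound 3 with one change: fluoro in place of bromo on an aromatic carbon. Nothing measured in the series separates bromo from fluoro at this place, so the expectation rests on compound 3 and the change alone. The expected step is a number 18 percentage points lower from compound 3 to compound 4 (beyond the scatter), a downward movement of moderate size, just beyond the scatter rather than a collapse. Compound 4 is thus estimated at 75% in this assay, within a range from 50% to 92%.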

Compound 4, a percentage reported as inhibition, at one concentration (the size of the read-out at that concentration, not a potency): 60%
Compound 4: middle estimate off by 15 percentage points, on the high side, and the stated range covers the measured number.
By their numbers in this assay, from the lowest: compounds 2 and 4 (each within the scatter of the next); then compound 1; then compound 3.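

Within the data shown here, the bromo to fluoro exchange gives the first reading of a single change: in this assay the step is a number 33 percentage points lower from compound 3 to compound 4 (beyond the scatter) and is large, so the choice of halogen on this aromatic carbon, meta to a fused ring and para to a fused ring, matters with the side chain of compound 3 held constant. Bromo and fluoro match in every count computed for the two groups, with one heavy atom each, no hydrogen-bond donors or acceptors and no net charge, so those counts do not separate them, and the step rests on the identity of the halogen alone. No measurement at hand bears on what lies behind this step.

The compounds shown leave open where chloro, methoxy or a plain hydrogen at this place would fall relative to bromo and fluoro. They also leave open whether the step carries over to other side chains, since the side chains of compound 1 and compound 2 appear here only with bromo on the ring.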